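Cyclohexyl in place of 3-(trifluoromethoxy)phenyl on compound 3

The source may hold more compounds than are shown below. What is called first, only, known or untested is meant among the compounds shown, and "the series" means these compounds.

Compound 1 `Cc1cn(C2CCN(Cc3cccc(Oc4cccc(F)c4)c3)CC2)c(=O)[nH]c1=O` gives > 64000 nM as a limit of the assay
Compound 2 `Cc1cn(C2CCN(Cc3cccc(Oc4ccc(Cl)c(Cl)c4)c3)CC2)c(=O)[nH]c1=O` gives 6100 nM
Compound 3 `Cc1cn(C2CCN(Cc3cccc(Oc4cccc(OC(F)(F)F)c4)c3)CC2)c(=O)[nH]c1=O` gives 5260 nM

Among the compounds with values here, in an ADME assay on MRC5 cells (Homo sapiens) for cytotoxicity, read by fluorescence and resazurin assay, with a stated time of 3 days (on this read-out higher numbers stand for weaker inhibition and lower numbers for stronger inhibition), compound 3 holds one of only two true numbers, and the other is its nearest neighbour. That gap is a 1.2-fold lower number from compound 2 to compound 3 (0.06 log units; within the scatter) and needs no further reading. Compound 4 `Cc1cn(C2CCN(Cc3cccc(OC4CCCCC4)c3)CC2)c(=O)[nH]c1=O` brings the change cyclohexyl in place of 3-(trifluoromethoxy)phenyl on an oxygen on an aromatic ring with cyclohexyl in place of 3-(trifluoromethoxy)phenyl on an oxygen on an aromatic ring. The group on that oxygen has mattered before, with large steps in an at least 10-fold lower number from compound 1 to compound 2 (1.02 log units; beyond the scatter) and in an at least 12-fold lower number from compound 1 to compound 3 (1.08 log units; beyond the scatter) as well. No cyclohexyl has been measured, so a moderate rise is expected, the estimated step being a 2.7-fold higher number from compound 3 to compound 4 (0.43 log units; beyond the scatter) in this case. For compound 4 the estimate is 14000 nM within an expected range from 4500 nM to 45000 nM in all.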

Compound 4, half-maximal inhibitory concentration: 23600 nM
Beside the measured number, compound 4's estimate is 1.7-fold (0.23 log units) below it, and the stated range covers the measured number.
By their numbers in this assay, from the lowest: compounds 3 and 2 (each within the scatter of the next); then compound 4. At a limit, above all of these: compound 1.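

Cyclohexyl on this oxygen gives the first non-aromatic ring here, and in this assay it separates clearly from both substituted phenyl groups, with a 4.5-fold higher number from compound 3 to compound 4 (0.65 log units; beyond the scatter) and a 3.9-fold higher number from compound 2 to compound 4 (0.59 log units; beyond the scatter). Against 3-fluorophenyl, the same group gives an at least 2.7-fold lower number from compound 1 to compound 4 (0.43 log units; beyond the scatter), so cyclohexyl falls inside the span the aromatic groups had opened. The value of compound 1 remains a limit of the assay: the limit of > 64000 nM in this assay, at which 1 of the 4 values shown sits.

The compounds shown leave open whether the aromatic ring itself or its chloro and trifluoromethoxy substituents set the number. An unsubstituted phenyl, a cyclopentyl or a piperidine on this oxygen would help separate the two.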